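The source may hold more compounds than are shown below. What is called first, only, known or untested is meant among the compounds shown, and "the series" means these compounds.

Measured compounds in a functional assay (spleen, spleen) for activation, with Mus musculus as the target; on this read-out higher numbers stand for an effect only at larger amounts of compound and lower numbers for an effect already at smaller amounts:
compound 1 `CCCCCNc1nc(N)c2nc(O)n(Cc3ccccc3)c2n1`, 0.1 uM
compound 2 `Cc1nc(N)c2nc(O)n(Cc3ccccc3)c2n1`, 1 uM

Compound 2 has the highest number of the two; compound 1 lies below it by a 10-fold higher number from compound 1 to compound 2 (1.00 log units; beyond the scatter). Compound 3 `CCCCc1nc(N)c2nc(O)n(Cc3ccccc3)c2n1` is not yet measured. It differs from compound 2 by propyl in place of hydrogen on a saturated chain carbon bound to an aromatic carbon. Among the compounds with values here, the one step that bears on this, a 10-fold higher number from compound 1 to compound 2 (1.00 log units; beyond the scatter), shows that shortening the chain raised the number, so a longer chain is expected to lower it, though compound 3 lacks the nitrogen of compound 1. A step of a 3.3-fold lower number from compound 2 to compound 3 (0.52 log units; beyond the scatter) downward is expected in this assay. Compound 3 is estimated at 0.3 uM, between 0.1 uM and 1.5 uM.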

Compound 3, minimum effective concentration: 0.03 uM
Beside the measured number, compound 3's estimate is 10-fold (1.00 log units) above it, outside the stated range (below it).
By their numbers in this assay, from the lowest: compound 3; then compound 1; then compound 2.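

In this assay the change of propyl in place of hydrogen on a saturated chain carbon bound to an aromatic carbon brings a 33-fold lower number from compound 2 to compound 3 (1.52 log units; beyond the scatter) and marks this position as highly responsive to chain length. Butyl in place of pentylamino brings a 3.3-fold lower number from compound 1 to compound 3 (0.52 log units; beyond the scatter) in the same read-out, so the amino nitrogen of compound 1 is not needed for a low number here. No data at hand explain either step.

As far as these compounds go, whether a longer chain such as hexyl lowers the number further remains open. So does the effect of a branched chain such as isobutyl or a terminal amine at this position.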